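The source may hold more compounds than are shown below. What is called first, only, known or untested is meant among the compounds shown, and "the series" means these compounds.

In a functional assay on U-87MG ATCC cells for cytotoxicity against U-87 MG (Homo sapiens), read by MTT assay, with a stated time of 72 h (a lower number here means a stronger inhibitor, a higher number a weaker inhibitor), compound 1 (`COc1ncc(-c2ccc3nc(NC(=O)NCCN(C)C)nn3c2)cc1NS(=O)(=O)c1ccc(F)cc1`) gives 980 nM, compound 2 (`CCCNC(=O)Nc1nc2ccc(-c3cnc(OC)c(NS(=O)(=O)c4ccc(F)cc4)c3)cn2n1`) gives 420 nM and compound 3 (`CCN(CC)CCNC(=O)Nc1nc2ccc(-c3cnc(OC)c(NS(=O)(=O)c4ccc(F)cc4F)c3)cn2n1`) gives 1060 nM. Compound 3 stands level with compound 1, within the scatter, while the value of compound 2 is the lower of that pair.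

Compound 4 (`CCN(CC)CCNC(=O)Nc1nc2ccc(-c3cnc(OC)c(NS(=O)(=O)c4ccc(Cl)cc4)c3)cn2n1`) departs from compound 3 in one place, with 4-chlorophenyl in place of 2,4-difluorophenyl on a sulfonyl sulfur. Within the data shown here, the only measured single-place step, a 2.3-fold lower number from compound 1 to compound 2 (0.37 log units; beyond the scatter), is methyl in place of dimethylamino on a saturated chain carbon. It is modest and concerns a different place in the molecule, so it gives no direct guide here. Among the measured compounds shown here, no measured step changes the group on the sulfonyl sulfur.

The value of compound 3, 1060 nM, therefore serves as the anchor, and no step beyond the scatter is expected in this assay. The estimated change is a 1.1-fold lower number from compound 3 to compound 4 (0.05 log units; within the scatter). Compound 4 is expected at 950 nM, with an estimated range of 420 nM to 2100 nM.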

Compound 4, half-maximal inhibitory concentration: 760 nM
For compound 4 the middle estimate is 1.3-fold (0.10 log units) above the measured one, and the stated range covers the measured number.
By their numbers in this assay, from the lowest: compounds 2, 4, 1 and 3 (each within the scatter of the next, the first and the last beyond it).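

In this assay, among these compounds, the first measured step at the group on the sulfonyl sulfur is a 1.4-fold lower number from compound 3 to compound 4 (0.14 log units; within the scatter), so 4-chlorophenyl in place of 2,4-difluorophenyl leaves compound 3 and compound 4 level. Within this pair, the group on the sulfonyl sulfur can therefore go from two fluorine atoms to one chlorine atom with no step beyond the scatter, though a single pair sets no pattern for this place. No measurement at hand bears on why the two stand level.

From the compounds shown here alone, it remains open whether other groups on the sulfonyl sulfur, such as 4-methoxyphenyl or a plain methyl, would also stay level with compound 3. Going by these compounds, it also remains open whether 4-chlorophenyl or 2,4-difluorophenyl would read the same on the chain carried by compound 2.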